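Halogen swap on the benzyl ring and Vero cell cytotoxicity

The compounds below may be only part of what the source reports. "The series", "measured", "known", "first", "only" and "open" are said of these compounds alone.

Compound 1 `CCOC(=O)c1cc(-c2cccc(OCc3cccc(Cl)c3)c2)on1`: > 128000 nM
Compound 2 `CCOC(=O)c1cc(-c2cccc(OCc3ccc(F)c(F)c3)c2)on1`: > 128000 nM

In an ADME assay on Vero cells (Chlorocebus sabaeus) for cytotoxicity, with a stated time of 72 h (on this read-out higher numbers stand for weaker inhibition and lower numbers for stronger inhibition), compound 1 gives > 128000 nM, which is a limit of the assay rather than a number. Compound 2 also gives > 128000 nM, again a limit. The step that the two limits leave unreadable from compound 1 to compound 2 is therefore unreadable, since both values sit at the limit of > 128000 nM in this assay, at which 2 of the 2 values shown sit. Compound 3 `CCOC(=O)c1cc(-c2cccc(OCc3ccc(F)cc3F)c2)on1` differs from compound 1 by 2,4-difluorophenyl in place of 3-chlorophenyl on a saturated chain carbon bound to an oxygen on an aromatic ring. Within the data shown here, the one related step supplies no size, so for compound 3 the expected step is a number no higher from compound 1 to compound 3 (the limit leaves the size open), nothing beyond the scatter in either direction. Compound 3 is estimated at 128000 nM, between 64000 nM and 256000 nM, most likely reported only as a limit.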

Compound 3, half-maximal inhibitory concentration: > 128000 nM
Compound 3: only a limit was reported; the forecaster's own chance of this, stated with the estimate: 85%; the middle value lies on the limit itself.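

Compound 3 joins compound 1 and compound 2 at the same limit, so no step among these compounds can be read: the limit of > 128000 nM in this assay, at which 3 of the 3 values shown sit.

Whether their halogen-bearing rings make any difference in this assay stays open, with only limits and no actual numbers shown.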